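Plasma half-life notes: methoxy to (nitrooxy)methyl on the benzoate

The compounds below may be only part of what the source reports. "The series", "measured", "known", "first", "only" and "open" are said of these compounds alone.

Measured compounds in an ADME assay on a cell-free system (plasma, Homo sapiens) for metabolic stability, with Plasma (Rattus norvegicus) as the target, read by HPLC, at pH 7.4; on this read-out higher numbers stand for a longer-lived compound and lower numbers for a shorter-lived compound:
compound 1 `CC(=O)Oc1ccccc1C(=O)O[C@H]1CO[C@H]2[C@@H]1OC[C@H]2OC(=O)c1ccccc1O`: 0.0825 h
compound 2 `CC(=O)Oc1ccccc1C(=O)O[C@H]1CO[C@H]2[C@@H]1OC[C@H]2OC(=O)c1snnc1C`: 0.0642 h
compound 3 `COc1ccccc1C(=O)O[C@@H]1CO[C@H]2[C@@H]1OC[C@@H]2OC(=O)c1ccccc1OC(C)=O`: 0.0578 h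

All three values sit close together. Compound 3 holds the lowest number of the three, but its nearest neighbour compound 2 and its furthest neighbour compound 1 both lie within the scatter of it, so no order among them can be read. The steps between the measured compounds are all small: a 1.3-fold lower number from compound 1 to compound 2 (0.11 log units; within the scatter), a 1.4-fold lower number from compound 1 to compound 3 (0.15 log units; within the scatter) and a 1.1-fold lower number from compound 2 to compound 3 (0.05 log units; within the scatter).

Compound 4 `CC(=O)Oc1ccccc1C(=O)O[C@H]1CO[C@H]2[C@@H]1OC[C@H]2OC(=O)c1ccccc1CO[N+](=O)[O-]` is not yet measured. Against compound 3 the change is (nitrooxy)methyl in place of methoxy on an aromatic carbon. Among the compounds with values here, no measured step touches a (nitrooxy)methyl group; the closest comparison is the hydrogen-to-methyl step on the ring oxygen, a 1.4-fold lower number from compound 1 to compound 3 (0.15 log units; within the scatter), which stayed within the scatter, as did the exchange of the whole aryl group in a 1.1-fold lower number from compound 2 to compound 3 (0.05 log units; within the scatter). Every change seen so far on this position of the shared core left the half-life unmoved, and the acetoxyphenyl ester common to all four compounds is unchanged.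

Compound 4 is therefore expected to stay in the same range, with a 1.0-fold higher number from compound 3 to compound 4 (0.02 log units; within the scatter) expected to fall within the scatter, and an estimated half-life of 0.06 h (range 0.03 h to 0.12 h).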

Compound 4, half-life: 0.045 h
The estimate for compound 4 lay 1.3-fold (0.12 log units) above the measured number, within the range that was stated.
By their numbers in this assay, from the lowest: compounds 4, 3, 2 and 1 (each within the scatter of the next).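

In this assay, (nitrooxy)methyl in place of methoxy on an aromatic carbon gives a 1.3-fold lower number from compound 3 to compound 4 (0.11 log units; within the scatter), so this larger change of substituent on the aryl ester still does not separate the half-life from that of the methoxy compound. Within the data shown here, the other two comparisons agree, with a 1.4-fold lower number from compound 2 to compound 4 (0.15 log units; within the scatter) and a 1.8-fold lower number from compound 1 to compound 4 (0.26 log units; within the scatter), the latter being the widest step so far and still not beyond the scatter. No supporting measurement bears on this result.

As far as these compounds go, all four compounds remain within the scatter of one another, so it is open whether any group at this position can move the half-life measurably. An amine or a carboxylic acid on this aromatic carbon, or a longer chain carrying the nitrooxy group, remains an open case.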